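This account rests on a few compounds, and the source may have more. Where it says the series, first, only, none or still open, it means among the compounds named here.

Working notes on the series, read in a functional assay on MGC-803 cells (Homo sapiens) for inhibition, read by sulforhodamine B assay; a higher number here means a weaker inhibitor, a lower number a stronger inhibitor. Compound 3 `CCOc1ccc(NC2=CC(=O)c3nc4n(c3C2=O)[C@H]2OC[C@@H](O)[C@H]2OC4)cc1` gives 1110 nM, and compound 1 `CCCc1ccc(NC2=CC(=O)c3nc4n(c3C2=O)[C@H]2OC[C@@H](O)[C@H]2OC4)cc1` gives 1560 nM. These two stand level, with a 1.4-fold lower number from compound 1 to compound 3 (0.15 log units; within the scatter). Compound 2 `O=C1C=C(NC2CCCCC2)C(=O)c2c1nc1n2[C@H]2OC[C@@H](O)[C@H]2OC1` reads > 8000 nM, which is a limit and not a number. Compound 3 stands clear of it, with an at least 7.2-fold lower number from compound 2 to compound 3 (0.85 log units; beyond the scatter), and the matching step from the other aryl compound is an at least 5.1-fold higher number from compound 1 to compound 2 (0.70 log units; beyond the scatter).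

Compound 4 `CCOc1ccccc1NC1=CC(=O)c2nc3n(c2C1=O)[C@H]1OC[C@@H](O)[C@H]1OC3` carries 2-ethoxyphenyl in place of 4-ethoxyphenyl on an amine nitrogen. Among the compounds with values here, no measured step moves a group around the aromatic ring, so the bearing is indirect. Only the swaps to and from cyclohexyl go beyond the scatter, and compound 4 keeps its aromatic ring. The exchange of propyl for ethoxy, a 1.4-fold lower number from compound 1 to compound 3 (0.15 log units; within the scatter), stays within the scatter. In this assay, no change beyond the scatter is therefore expected, with a slight lean toward a higher number. The estimated step is a 1.6-fold higher number from compound 3 to compound 4 (0.21 log units; within the scatter). Compound 4 is estimated at 1800 nM, with an expected range of 600 nM to 5000 nM.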

Compound 4, half-maximal inhibitory concentration: 2450 nM
For compound 4 the middle estimate is 1.4-fold (0.13 log units) below the measured one, and the stated range covers the measured number.
By their numbers in this assay, from the lowest: compounds 3, 1 and 4 (each within the scatter of the next, the first and the last beyond it). At a limit, above all of these: compound 2.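

In this assay, where the ethoxy sits on the aromatic ring matters: the only step shown that changes nothing else gives a 2.2-fold higher number from compound 3 to compound 4 (0.34 log units; beyond the scatter), while the comparison with the other aryl compound gives a 1.6-fold higher number from compound 1 to compound 4 (0.20 log units; within the scatter). An aromatic ring on the amine nitrogen with ethoxy moved to the 2-ethoxyphenyl arrangement still separates from cyclohexyl, with an at least 3.2-fold lower number from compound 2 to compound 4 (0.51 log units; beyond the scatter). The reading for compound 2 is a limit and not a number, so that step gives only a bound: the limit of > 8000 nM in this assay, at which 1 of the 4 values shown sits.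

As far as these compounds go, whether the same shift on the ring holds for groups other than ethoxy, such as an amine or a carboxylic acid, stays open. The compounds shown also do not tell why 4-ethoxyphenyl and 2-ethoxyphenyl read apart.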